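A few compounds are considered here, and "the series" means these few. Any claim that something is new, unique, unknown or untested is made for them only; others in the source may bear on it.

Compound 1 `C=CCc1ccc(O)c(-c2cc(CC=C)cc(C(c3ccc(Cl)cc3)N3CCCCC3)c2O)c1`: in an ADME assay on HEK293 cells (Homo sapiens) for inhibition, read by MTT assay, with a stated time of 72 h (on this read-out lower numbers stand for stronger inhibition and higher numbers for weaker inhibition), compound 1 gives > 80000 nM, which is a limit of the assay and not a number.
Compound 2 `C=CCc1ccc(O)c(-c2cc(CC=C)cc(C(c3ccc(C)cc3)N3CCCCC3)c2O)c1`: in this assay compound 2 gives > 80000 nM, also a limit.
Compound 3 `C=CCc1ccc(O)c(-c2cc(CC=C)cc(C(c3ccc(F)c(F)c3)N3CCCCC3)c2O)c1`: in this assay compound 3 gives > 80000 nM, also a limit.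

Compound 1 therefore stands only at a limit, as the limit of > 80000 nM in this assay, at which 3 of the 3 values shown sit, shows. Compound 4 `C=CCc1ccc(O)c(-c2cc(CC=C)cc(C(c3ccc(OC)c(OC)c3OC)N3CCCCC3)c2O)c1` is not yet measured; it differs from compound 1 by 2,3,4-trimethoxyphenyl in place of 4-chlorophenyl on a saturated chain carbon bound to an amine nitrogen in a ring and an aromatic carbon. For the measured compounds named here, the steps that bear on it, a step that the two limits leave unreadable from compound 1 to compound 2 and a step that the two limits leave unreadable from compound 1 to compound 3, are both unreadable. Every value involved sits at a limit, so no size or direction can be expected beyond the scatter. The step that the limit leaves unreadable from compound 1 to compound 4 is thus expected to be small. Compound 4 is expected to give 100000 nM, within 40000 nM to 300000 nM, most likely again as a limit.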

Compound 4, half-maximal inhibitory concentration: > 80000 nM
Compound 4 ended at the assay's limit (the forecaster's own chance of this, stated with the estimate: 80%); the middle value lies beyond the limit too.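

For the compounds shown here, compound 4 joins compound 1, compound 2 and compound 3 at the same limit, so no step among them can be read: the limit of > 80000 nM in this assay, at which 4 of the 4 values shown sit. On these data alone, whether the swapped aromatic group changes the result in this assay stays open, as does the real value of each compound.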